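A few compounds are considered here, and "the series" means these few. Any claim that something is new, unique, unknown or untested is made for them only; others in the source may bear on it.

Measured compounds:
Compound 1, `Cc1noc(-c2ccccc2NCC2=NCCN2)n1`: < 5020 nM
Compound 2, `FC(F)(F)c1cccnc1-c1ccccc1NCC1=NCCN1`: < 100000 nM

In a functional assay for activation of Alpha-1B adrenergic receptor (Homo sapiens), read by calcium flux (a higher number here means that more compound is needed for the effect, a lower number that less compound is needed), compound 1 gives < 5020 nM, which is a limit of the assay and not a number. Compound 2 gives < 100000 nM, likewise only a limit. Compound 1 thus stands at the limit of < 5020 nM in this assay, at which 1 of the 2 values shown sits, while the other value sits at the limit of < 100000 nM in this assay, at which 1 of the 2 values shown sits, so no numbered step between the two is known. Compound 3, `CCO/N=C(\C)c1ccccc1NCC1=NCCN1`, differs from compound 1 by a group of 6 heavy atoms (4 carbon, 1 nitrogen, 1 oxygen; no ring) in place of a group of 6 heavy atoms (3 carbon, 2 nitrogen, 1 oxygen; one five-membered aromatic ring with 3 hetero atoms), on an aromatic carbon. Within the data shown here, with no measured step for such a change, no shift beyond the usual scatter is expected, in either direction. For compound 3 the estimate in this assay is 3000 nM, ranging from 500 nM to 20000 nM. This means an expected step that the limit leaves unreadable from compound 1 to compound 3.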

Compound 3, half-maximal effective concentration: < 5020 nM
Compound 3: only a limit was reported; the forecaster's own chance of this, stated with the estimate: 60%; the middle value is on the limit's open side.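

In this assay compound 3 gives < 5020 nM, which is a limit and not a number. No step can be read between compound 1 and compound 3. The compounds shown leave open how the 3-methyl-1,2,4-oxadiazol-5-yl group and the group replacing it in compound 3 actually compare in this assay.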